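The source may hold more compounds than are shown below. What is called first, only, known or untested is meant among the compounds shown, and "the series" means these compounds.

In an ADME assay on microsomes from liver (Mus musculus) for metabolic stability, read by LC-MS, with a stated time of 10 min (a lower number here means that less of the compound is left, a higher number that more of the compound is left), the measured compounds stand as follows:
compound 1 `CN(C[C@H]1Cc2c(cccc2N2CCN(C3COC3)CC2)CN1)[C@H]1CCCc2cccnc21` gives 50.8%;
compound 2 `CN(C[C@H]1Cc2c(cccc2N2CCN3CCC[C@@H]3C2)CN1)[C@H]1CCCc2cccnc21` gives 36.7%.

Within the data shown here, compound 1 holds the higher of the two numbers, and the only known step, a number 14.1 percentage points lower from compound 1 to compound 2 (beyond the scatter), runs downward. Compound 3 `CN(C[C@H]1Cc2c(cccc2N2CCN(c3ncccn3)CC2)CN1)[C@H]1CCCc2cccnc21` differs from compound 1 by pyrimidin-2-yl in place of oxetan-3-yl on an amine nitrogen in a ring. Among the measured compounds shown here, no measured step shows this exact exchange, so the one known step is only a loose guide; it suggests that changes at this part of the shared core can lower the number modestly. Compound 3 is therefore expected to give 42% (range 22% to 62%), a step of a number 8.8 percentage points lower from compound 1 to compound 3 (within the scatter) that is expected to stay near the scatter.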

Compound 3, percent of the compound remaining: 35.1%
Beside the measured number, compound 3's estimate is 6.9 percentage points above it, and the stated range covers the measured number.
By their numbers in this assay, from the lowest: compounds 3 and 2 (each within the scatter of the next); then compound 1.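

In this assay, a number 15.7 percentage points lower from compound 1 to compound 3 (beyond the scatter) follows when pyrimidin-2-yl replaces oxetan-3-yl on the amine nitrogen in a ring. The six-membered ring carrying that nitrogen stays the same in both compounds, so this exchange shows that the group on the nitrogen can by itself move the number beyond the scatter. Going by these compounds, whether a methyl or an acetyl group on that nitrogen would stay nearer compound 1 or nearer compound 3 remains open. No measurement shown here accounts for the step.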